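The compounds below may be only part of what the source reports. "The series", "measured", "known", "first", "only" and "open" are said of these compounds alone.

Compound 1 `CCc1cccc2c(OC)c(-c3occ(C)c3C(=S)OC)ccc12` carries a methyl thioester on its five-membered ring. In a functional assay on MDA-MB-231 cells (Homo sapiens) for cytotoxicity, read by MTT assay, with a stated time of 72 h (on this read-out higher numbers stand for an effect only at larger amounts of compound and lower numbers for an effect already at smaller amounts), compound 1 gives 5.8 ug/mL, the higher of the two numbers obtained so far. Compound 2 `CCOc1c(-c2occ(C)c2CO)ccc2c(CC)cccc12` gives 1.4 ug/mL, a lower number, and the gap between compound 2 and compound 1 lies beyond the usual scatter. Compound 3 `CCc1cccc2c(OC(C)=O)c(-c3occ(C)c3COC(C)=O)ccc12` is recorded at > 10 ug/mL, which is a limit of this assay rather than a number. That value stands at the limit of > 10 ug/mL in this assay, at which 1 of the 3 values shown sits. Compound 4 `CCc1cccc2c(OC)c(-c3occ(C)c3COCC(F)(F)F)ccc12` has not yet been measured. It differs from compound 1 in one place: a group of 7 heavy atoms (3 carbon, 1 oxygen, 3 fluorine; no ring) in place of a group of 4 heavy atoms (2 carbon, 1 oxygen, 1 sulfur; no ring), on an aromatic carbon. Going by the values given here, no step between measured compounds corresponds to such a change, so the expected size can rest only on the spread of the three values shown. In this assay compound 4 is expected to give 5 ug/mL, within a range from 1.5 ug/mL to 15 ug/mL. That estimate amounts to a 1.2-fold lower number from compound 1 to compound 4 (0.06 log units; within the scatter), a step expected to stay within the scatter.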

Compound 4, concentration for half-maximal effect: 5.3 ug/mL
Beside the measured number, compound 4's estimate is 1.1-fold (0.03 log units) below it; the measured number falls inside the stated range.
By their numbers in this assay, from the lowest: compound 2; then compounds 4 and 1 (each within the scatter of the next). At a limit, above all of these: compound 3.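

In this assay, going by these compounds alone, the exchange of the methyl thioester for (2,2,2-trifluoroethoxy)methyl, on an aromatic carbon of the five-membered aromatic ring with 1 oxygen, gives a 1.1-fold lower number from compound 1 to compound 4 (0.04 log units; within the scatter) and is the first single-place change seen at this position. The position therefore accepts a larger group without sulfur and without a double bond outside aromatic rings, and the number does not move beyond the scatter, so neither feature of the thioester is needed to keep the value seen here. Nothing measured among the data shown explains why the two groups give such similar values.

The compounds shown leave open whether an amine or a carboxylic acid at this position would shift the number beyond the scatter. They also leave open whether a longer chain ending in a trifluoromethyl group would do so.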